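The source may hold more compounds than are shown below. What is called first, only, known or untested is meant among the compounds shown, and "the series" means these compounds.

In a functional assay on the whole organism with Rattus norvegicus as the target (a lower number here means that less compound is needed, a higher number that more compound is needed for the effect), two compounds with a shared core have been measured so far. Compound 1 (`CCOC(=O)C(=O)Nc1cccc(N(CC)CC)c1C#N`) gives 0.7 mg/kg, and compound 2 (`CCOC(=O)C(=O)Nc1cccc(OC(C)C)c1C#N`) gives 2 mg/kg, the higher of the two numbers, so more of compound 2 is needed for the effect. The next structure, compound 3 (`CCOC(=O)C(=O)Nc1cccc(F)c1C#N`), carries fluoro in place of isopropoxy on an aromatic carbon, ortho to a cyano group: fluoro in place of isopropoxy on an aromatic carbon. Within the data shown here, only one measured step can guide the expectation: a 2.9-fold higher number from compound 1 to compound 2 (0.46 log units; beyond the scatter). That step exchanges a different pair of groups, so it is a rough guide at best. A step of similar modest size towards a higher number seems likeliest, although no change beyond the scatter remains possible. The expected change is a 2.0-fold higher number from compound 2 to compound 3 (0.30 log units; within the scatter). Compound 3 is estimated at 4 mg/kg, with an expected range from 1 mg/kg to 12 mg/kg.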

Compound 3, dose for half-maximal effect: 1.2 mg/kg
Estimate against measurement, compound 3: 3.3-fold (0.52 log units) above; measured number inside the range.
By their numbers in this assay, from the lowest: compounds 1, 3 and 2 (each within the scatter of the next, the first and the last beyond it).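

In this assay, exchanging isopropoxy for fluoro on this aromatic carbon, ortho to a cyano group, gives a 1.7-fold lower number from compound 2 to compound 3 (0.22 log units; within the scatter) and so stays within the usual scatter, even though the carbons and the oxygen of isopropoxy are gone. Exchanging diethylamino for fluoro gives a 1.7-fold higher number from compound 1 to compound 3 (0.23 log units; within the scatter) and is also within the scatter, so compound 3 cannot be told apart from either compound 1 or compound 2, although those two differ beyond the scatter. At this position, then, fluoro is compatible with a measurable effect in the whole animal, and no measurement at hand says what lies behind these numbers.

A plain amino group or a methoxy group here could show whether the difference between compound 1 and compound 2 follows the nitrogen or oxygen attached to the ring or the alkyl groups it carries. Hydrogen or chloro in the same place would show how far the result for fluoro extends to other simple replacements.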